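From (pyridin-2-yl)carbonyl to (piperidin-2-yl)methyl

The source may hold more compounds than are shown below. What is called first, only, known or untested is meant among the compounds shown, and "the series" means these compounds.

Going by the values given here, in a physicochemical assay for solubility, read by chemiluminescence, measured as kinetic solubility (a lower number here means a less soluble compound, a higher number a more soluble compound), compound 2 `O=C(c1ccccn1)N1CCC2(CCN(c3nccc(NCc4ccc(Cl)cc4Cl)n3)CC2)C1` gives 17 ug/mL as the lower of the two numbers so far, and compound 1 `O=C(C1CCCN1)N1CCC2(CCN(c3nccc(NCc4ccc(Cl)cc4Cl)n3)CC2)C1` gives the higher number of 79 ug/mL (a gap beyond the scatter). Compound 3 `Clc1ccc(CNc2ccnc(N3CCC4(CCN(CC5CCCCN5)C4)CC3)n2)c(Cl)c1` is still unmeasured and differs from compound 2 in one place ((piperidin-2-yl)methyl in place of (pyridin-2-yl)carbonyl on an amine nitrogen in a ring), with (piperidin-2-yl)methyl in place of (pyridin-2-yl)carbonyl on an amine nitrogen in a ring. Among the compounds with values here, only one measured step bears on this (a 4.6-fold lower number from compound 1 to compound 2 (0.67 log units; beyond the scatter)), a modest one beyond the scatter, where pyridin-2-yl replaced pyrrolidin-2-yl on a carbonyl carbon. That step went from a non-aromatic ring to an aromatic one, and the new change runs the other way. Within the data shown here, the carbonyl also leaves, and no measured pair covers that. A step of similar size towards a higher number in this assay is therefore expected, with real uncertainty. The expected step is a 3.5-fold higher number from compound 2 to compound 3 (0.55 log units; beyond the scatter) (an estimate). The estimated value for compound 3 is 60 ug/mL (range 22 ug/mL to 150 ug/mL).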

Compound 3, solubility: 182 ug/mL
For compound 3 the middle estimate is 3.0-fold (0.48 log units) below the measured one, outside the stated range (above it).
By their numbers in this assay, from the lowest: compound 2; then compound 1; then compound 3.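

In this assay, putting (piperidin-2-yl)methyl in place of (pyridin-2-yl)carbonyl on this amine nitrogen in a ring gives an 11-fold higher number from compound 2 to compound 3 (1.03 log units; beyond the scatter), the largest step seen so far at this position. An aromatic ring leaving cannot be the whole story: compound 1 also has a non-aromatic ring and no aromatic ring in this group, yet the comparison with it still shows a 2.3-fold higher number from compound 1 to compound 3 (0.36 log units; beyond the scatter). Of the three groups, the one without a carbonyl gives the highest number. Nothing measured here accounts for these shifts.

The ring and the carbonyl both change in each of these two steps, so their separate contributions remain unresolved. A (pyrrolidin-2-yl)methyl or a (piperidin-2-yl)carbonyl group on the same nitrogen would pull the two apart.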